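Swapping fluoro for methoxy on the sulfanyl ring

The compounds below may be only part of what the source reports. "The series", "measured", "known", "first", "only" and "open" are said of these compounds alone.

Of the compounds shown here, three sharing one core have been tested in a functional assay on NCI-H23 cells (Homo sapiens) for inhibition, read by sulforhodamine B assay, with a stated time of 48 h; a lower number here means that less compound is tolerated, a higher number that more compound is tolerated. Compound 1 `Nc1cc(N)c2nc(-c3ccccc3)c(NCc3ccc(Cl)c(Cl)c3)nc2c1` gives 55000 nM. Compound 3 `COc1ccc(CNc2nc3cc(N)cc(N)c3nc2-c2ccccc2)cc1` gives 70800 nM. Compound 2 `Nc1cc(N)c2nc(-c3ccccc3)c(Sc3ccc(F)cc3)nc2c1` gives 81300 nM. Compound 2 sits at the upper end of these three numbers, but its gap to compound 3 and its gap to compound 1 both lie within the usual scatter, so no real separation between the three can be claimed.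

Compound 4 `COc1ccc(Sc2nc3cc(N)cc(N)c3nc2-c2ccccc2)cc1` is not yet measured. It differs from compound 2 in one place: methoxy in place of fluoro on an aromatic carbon

Going by the values given here, only one measured step bears on this, and only loosely: a 1.3-fold higher number from compound 1 to compound 3 (0.11 log units; within the scatter). There, a methoxy-bearing ring replaced a dichloro-bearing ring on a different part of the molecule, and the number hardly moved. That step, together with the flat picture across compounds 1, 2 and 3, gives no reason to expect that a methoxy in place of fluoro will shift this assay beyond the scatter; the expected step is a 1.0-fold lower number from compound 2 to compound 4 (0.01 log units; within the scatter).

Compound 4 is therefore estimated to give 80000 nM in this assay, with a range from 40000 nM to 160000 nM.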

Compound 4, concentration lethal to 50% of the cells: < 100000 nM
Compound 4: only a limit was reported; the forecaster's own chance of this, stated with the estimate: 10%; the middle value is on the limit's open side.
By their numbers in this assay, from the lowest: compounds 1, 3 and 2 (each within the scatter of the next).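

Compound 4 gives < 100000 nM in this assay, and this is a limit, not a number. The step from compound 2 to compound 4 therefore cannot be read. The compounds shown leave open whether methoxy in place of fluoro on an aromatic carbon changes the number in this assay at all, and if so, in which direction.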